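Indolylmethyl in Place of Hydroxyquinolinyl on the Shared Core

A few compounds are considered here, and "the series" means these few. Any claim that something is new, unique, unknown or untested is made for them only; others in the source may bear on it.

Compound 1, `Cn1c(=O)c(S(=O)(=O)c2ccc(F)cc2F)cc2cnc(Nc3ccc4[nH]c(C(=O)O)cc4c3)nc21`, gives 10000 nM in a functional assay on DU-145 cells (Homo sapiens) for inhibition, read by trypan blue exclusion, with a stated time of 72 h; a higher number here means a weaker inhibitor, a lower number a stronger inhibitor.
Compound 2, `Cn1c(=O)c(S(=O)(=O)c2ccc(OC(=O)CCCCC3SCC4NC(=O)NC43)cc2)cc2cnc(Nc3ccc4[nH]ccc4c3)nc21`, gives 150 nM in this assay.
Compound 3, `Cn1c(=O)c(S(=O)(=O)c2ccc(F)cc2F)cc2cnc(Nc3ccc4cccc(O)c4n3)nc21`, gives 5000 nM in this assay.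

Compound 3 holds the second highest of the three numbers. Its nearest neighbour is compound 1, reached by a 2.0-fold lower number from compound 1 to compound 3 (0.30 log units; within the scatter), a step that stays within the scatter. Within the data shown here, compound 2 lies furthest away, with a number far lower than that of compound 3, beyond the scatter; the two differ in two places, so no single step links them.

Compound 4, `Cn1c(=O)c(S(=O)(=O)c2ccc(F)cc2F)cc2cnc(NCc3ccc4[nH]ccc4c3)nc21`, is the next compound. It differs from compound 3 by (1H-indol-5-yl)methyl in place of 8-hydroxyquinolin-2-yl on a nitrogen on an aromatic ring. Among the measured compounds shown here, no measured step bears directly on this change: the only measured step, a 2.0-fold lower number from compound 1 to compound 3 (0.30 log units; within the scatter), alters the same position but stays within the scatter. Compound 2 carries a related indolyl group on that nitrogen, without the methylene and with a different sulfonyl arene, and gives 150 nM.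

Compound 4 is therefore expected to give 1500 nM, within a range of 300 nM to 8000 nM. The step of a 3.3-fold lower number from compound 3 to compound 4 (0.52 log units; beyond the scatter) is expected to run toward a lower number, with wide uncertainty.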

Compound 4, half-maximal inhibitory concentration: 100000 nM
Estimate against measurement, compound 4: 67-fold (1.82 log units) below, and the stated range ends below it.
By their numbers in this assay, from the lowest: compound 2; then compounds 3 and 1 (each within the scatter of the next); then compound 4.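

Among these compounds, at the nitrogen on an aromatic ring, the one earlier exchange had stayed within the scatter, so it gave no sign that the number in this assay responds to the group placed there. The (1H-indol-5-yl)methyl group now shows that it does, with a 20-fold higher number from compound 3 to compound 4 (1.30 log units; beyond the scatter) against 8-hydroxyquinolin-2-yl and a 10-fold higher number from compound 1 to compound 4 (1.00 log units; beyond the scatter) against 2-carboxy-1H-indol-5-yl, both beyond the scatter and both toward a weaker inhibitor. Nothing at hand accounts for the size of these steps.

Compound 4 brings a different ring system and a methylene onto that nitrogen in a single change, so the two contributions cannot be told apart here, and compound 2, which carries an indolyl group on the same nitrogen without the methylene, also differs in its sulfonyl arene. On these data alone, it also remains open how the number would respond to an amine or a carboxylic acid on the indole ring of the (1H-indol-5-yl)methyl group, or to a longer chain in place of the methylene.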